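Aryl methyl addition on the oxadiazolylmethoxy ketone series

A few compounds are considered here, and "the series" means these few. Any claim that something is new, unique, unknown or untested is made for them only; others in the source may bear on it.

Measured so far:
compound 1 `C=C(C)C(=O)c1ccc(OCc2nc(C)no2)cc1C` 5000 nM
compound 2 `C=C(C)C(=O)c1ccc(OCc2nc(-c3ccc(F)cc3)no2)cc1C` 3500 nM

In an assay on HL-60 cells for inhibition of glutathione S-transferase P (Homo sapiens) (on this read-out higher numbers stand for weaker inhibition and lower numbers for stronger inhibition), compound 1 gives 5000 nM and holds the highest number of the two measured; the nearest is compound 2, and the step of a 1.4-fold lower number from compound 1 to compound 2 (0.15 log units; within the scatter) separates them, so the two are not distinguished. Compound 3 `C=C(C)C(=O)c1ccc(OCc2nc(C)no2)c(C)c1C` has not yet been measured in this assay. It differs from compound 1 by methyl in place of hydrogen on an aromatic carbon. For the measured compounds named here, the only measured step, from compound 1 to compound 2, changes a different position and concerns a different kind of group, so it says nothing direct about a methyl entering here; no step bears on the change. With nothing to indicate a shift in either direction, the expectation for compound 3 is a number close to that of compound 1, with any step no change at the digits printed from compound 1 to compound 3 (within the scatter) expected to stay within the scatter. The estimate for compound 3 in this assay is 5000 nM, with a range from 2000 nM to 12000 nM.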

Compound 3, half-maximal inhibitory concentration: 4000 nM
The estimate for compound 3 lay 1.3-fold (0.10 log units) above the measured number, within the range that was stated.
By their numbers in this assay, from the lowest: compounds 2, 3 and 1 (each within the scatter of the next).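

Methyl in place of hydrogen on this aromatic carbon, ortho to a methyl group and to the group of 8 heavy atoms, gives a 1.3-fold lower number from compound 1 to compound 3 (0.10 log units; within the scatter) in this assay and leaves the two compounds undistinguished. For the compounds shown here, this is the first reading at this position, and it shows that the ring carbon can carry a methyl with no readable shift on this read-out. No measurement shown here offers an explanation for this result.

On these data alone, whether an amine, a methoxy group or a longer chain on this carbon would stay within the scatter of compound 1 remains open. Also open, as far as these compounds go, is whether the same methyl would read the same way with the 4-fluorophenyl group of compound 2 in place of the methyl on the oxadiazole.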